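This account rests on a few compounds, and the source may have more. Where it says the series, first, only, none or still open, it means among the compounds named here.

Three compounds have been measured in an assay on membranes from CHO cells for displacement of a labelled ligand from adenosine receptor A1 (Homo sapiens), read by scintillation counting, with a stated time of 60 min, tested at 1 uM; a higher number here means more inhibition at the concentration tested (going by the name of the read-out), a lower number less inhibition:

compound 1, `CC1=C(C(=O)OCc2ccccc2)C(c2ccco2)NC(=O)N1`, gives 36%
compound 2, `CC1=C(C(=O)OCc2ccccc2)C(c2ccoc2)NC(=O)N1`, gives 41%
compound 3, `CC1=C(C(=O)OC(C)(C)C)C(c2ccsc2)NC(=O)N1`, gives 15%

Compound 3 stands lowest of the three; compound 1 lies above it by a gap beyond the scatter, and compound 2 further still. Among the measured compounds shown here, the only step between compounds that differ in one place is a number 5 percentage points higher from compound 1 to compound 2 (within the scatter), which swaps the five-membered ring and leaves the ester untouched, so it says nothing about the ester. Compound 4, `CC1=C(C(=O)OCc2ccccc2)C(c2ccsc2)NC(=O)N1`, keeps the thiophen-3-yl ring of compound 3 and differs from it in a single place: benzyl in place of tert-butyl on an oxygen next to a carbonyl group. For the measured compounds named here, no measured pair isolates this change. Compounds 1 and 2, which both carry the benzyl ester, sit well above compound 3, but they also carry a different ring, so the benzyl ester cannot be credited alone. A rise is nonetheless expected in this assay, with a step of a number 17 percentage points higher from compound 3 to compound 4 (beyond the scatter) estimated for compound 4. Compound 4 is estimated at 32%, within a range from 14% to 50%.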

Compound 4, a percentage reported as inhibition, at one concentration (the size of the read-out at that concentration, not a potency): 57%
The estimate for compound 4 lay 25 percentage points below the measured number; the measured number lies above the stated range.
By their numbers in this assay, from the lowest: compound 3; then compounds 1 and 2 (each within the scatter of the next); then compound 4.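

In this assay the group on the oxygen next to the carbonyl group now has a clean test: with the thiophen-3-yl ring held fixed, benzyl in place of tert-butyl gives a number 42 percentage points higher from compound 3 to compound 4 (beyond the scatter) and so matters by itself. The ring also counts when benzyl is present: thiophen-3-yl in place of furan-3-yl gives a number 16 percentage points higher from compound 2 to compound 4 (beyond the scatter) and thiophen-3-yl in place of furan-2-yl gives a number 21 percentage points higher from compound 1 to compound 4 (beyond the scatter) in a series where the swap between the two furan rings stayed within the scatter. Nothing shown here explains either rise. Among the compounds shown, tert-butyl appears only with thiophen-3-yl, so it remains open whether benzyl would bring a similar rise with either furan ring. Also open, on these data alone, is how a longer chain such as phenethyl, or an amine on that chain, would compare with benzyl.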